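A few compounds are considered here, and "the series" means these few. Any claim that something is new, unique, unknown or untested is made for them only; others in the source may bear on it.

Measured compounds:
compound 1, `Cc1c(/C=C/[S+](C)[O-])oc2ccccc2c1=O` — 1500 nM
compound 2, `C[S+]([O-])/C=C/c1cc(=O)c2cc(Cl)ccc2o1` — 1700 nM
compound 3, `COc1cccc2oc(/C=C/[S+](C)[O-])cc(=O)c12` — 3800 nM

Three compounds on a shared core were tested in a functional assay on A549 cells (Homo sapiens) for cytotoxicity, with a stated time of 48 h; a lower number here means a stronger inhibitor, a higher number a weaker inhibitor. Compound 2 holds the second highest number of the three; compound 1 lies within the scatter of it, while compound 3 lies beyond the scatter, with the higher number. Compound 4 `CCCCOc1ccc2oc(/C=C/[S+](C)[O-])cc(=O)c2c1` differs from compound 2 in one place: butoxy in place of chloro on an aromatic carbon. Among the compounds with values here, no step between measured compounds bears on this change, and the measured values sit in a narrow band, so only a small shift is expected. The step expected here, a 1.5-fold higher number from compound 2 to compound 4 (0.17 log units; within the scatter), is modest and, if anything, toward a weaker inhibitor. Compound 4 is therefore estimated at about 2500 nM, within a range from 1000 nM to 6500 nM.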

Compound 4, half-maximal inhibitory concentration: 1400 nM
For compound 4 the middle estimate is 1.8-fold (0.25 log units) above the measured one; the range from low to high includes it.
By their numbers in this assay, from the lowest: compounds 4, 1 and 2 (each within the scatter of the next); then compound 3.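

In this assay, butoxy in place of chloro on this aromatic carbon gives a 1.2-fold lower number from compound 2 to compound 4 (0.08 log units; within the scatter) and so leaves the two compounds indistinguishable, although butoxy brings 5 heavy atoms and a hydrogen-bond acceptor where chloro has 1 heavy atom and none. Within the data shown here, this is the first step to bear on this position, and it shows that the position accepts a chain without a shift beyond the scatter. No measurement is available to explain this result. The compounds shown leave open whether an amine, a carboxylic acid or a longer chain on this carbon would also stay within the scatter of compound 2.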